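Removing a Nitro Group: What to Expect for Compound 3

The compounds below may be only part of what the source reports. "The series", "measured", "known", "first", "only" and "open" are said of these compounds alone.

In an ADME assay on 184B5 cells (Homo sapiens) for cytotoxicity, read by MTT assay, with a stated time of 72 h (a lower number here means a stronger inhibitor of growth, a higher number a weaker inhibitor of growth), compound 2 `N#C[Se]c1ccc(NC(=O)OCc2ccc([N+](=O)[O-])cc2)cc1` gives 18000 nM. Compound 1 `CC(C)COC(=O)Nc1ccc([Se]C#N)cc1` gives 21600 nM in this assay, a number within the usual scatter of that of compound 2, so the two cannot be told apart. Compound 3 `N#C[Se]c1ccc(NC(=O)OCc2ccccc2)cc1` has not yet been measured. It differs from compound 2 in one place: hydrogen in place of nitro on an aromatic carbon. Within the data shown here, no measured pair shows this change, so its effect is unknown from these data. The expected step, a 1.1-fold higher number from compound 2 to compound 3 (0.05 log units; within the scatter) in this assay, is estimated to be no larger than the scatter in either direction. The estimated value for compound 3 is 20000 nM, with a range from 9000 nM to 45000 nM.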

Compound 3, concentration for total growth inhibition: 21900 nM
For compound 3 the middle estimate is 1.1-fold (0.04 log units) below the measured one; the range from low to high includes it.
By their numbers in this assay, from the lowest: compounds 2, 1 and 3 (each within the scatter of the next).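

Hydrogen in place of nitro on the aromatic carbon gives a 1.2-fold higher number from compound 2 to compound 3 (0.09 log units; within the scatter) in this assay, so this position tolerates losing the nitro group without a readable shift. Phenyl in place of isopropyl on the saturated chain carbon gives a 1.0-fold higher number from compound 1 to compound 3 (0.01 log units; within the scatter), so that swap cannot be told from repeat scatter either. No measurement here offers a reason for these matching numbers.

On these data alone, whether an amine or a carboxylic acid on that aromatic carbon would move the number remains open. So does the effect of a longer chain on the carbamate oxygen.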